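Acetoxymethyl for methoxy on a benzoyl-pyrrole core

The source may hold more compounds than are shown below. What is called first, only, known or untested is meant among the compounds shown, and "the series" means these compounds.

The three measured compounds share one core and differ only in a single group on the benzoyl ring. Compound 1 `O=C(c1ccc(F)cc1)c1ccn(-c2ccc3c(c2)B(O)OC3)c1` carries fluoro there, and in an ADME assay on L929 cells (Mus musculus) for cytotoxicity, read by resazurin assay, with a stated time of 72 h (a higher number here means a weaker inhibitor, a lower number a stronger inhibitor), compound 1 gives > 10 ug/mL, which is a limit of the assay and not a number. Compound 2 `Cc1ccc(C(=O)c2ccn(-c3ccc4c(c3)B(O)OC4)c2)cc1` carries methyl, and in this assay compound 2 gives > 10 ug/mL, again a limit. Compound 3 `COc1ccc(C(=O)c2ccn(-c3ccc4c(c3)B(O)OC4)c2)cc1` carries methoxy, and in this assay compound 3 gives > 10 ug/mL, also a limit. The steps among them, a step that the two limits leave unreadable from compound 1 to compound 2, a step that the two limits leave unreadable from compound 1 to compound 3 and a step that the two limits leave unreadable from compound 2 to compound 3, therefore cannot be sized, because every value sits at the limit of > 10 ug/mL in this assay, at which 3 of the 3 values shown sit. Compound 4 `CC(=O)OCc1ccc(C(=O)c2ccn(-c3ccc4c(c3)B(O)OC4)c2)cc1` differs from compound 3 by acetoxymethyl in place of methoxy on an aromatic carbon. Among the compounds with values here, none of the measured steps can be read, so none gives a measurable size to carry over. Because compound 3 sits at the limit of > 10 ug/mL in this assay, at which 3 of the 3 values shown sit, alongside the others, compound 4 is expected to stay there too, with an estimated step that the limit leaves unreadable from compound 3 to compound 4. Compound 4 is accordingly estimated at 20 ug/mL, within a range from 8 ug/mL to 60 ug/mL.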

Compound 4, half-maximal inhibitory concentration: 10 ug/mL
Estimate against measurement, compound 4: 2.0-fold (0.30 log units) above; the range from low to high includes it.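

Within the data shown here, compound 4 is the first compound with a change at this position to give a number rather than a limit in this assay: compound 4 gives 10 ug/mL, which is a number no higher from compound 3 to compound 4 (the limit leaves the size open). It is likewise a number no higher from compound 2 to compound 4 (the limit leaves the size open) and a number no higher from compound 1 to compound 4 (the limit leaves the size open). The sizes of these steps still cannot be read, because the other values remain limits: the limit of > 10 ug/mL in this assay, at which 3 of the 4 values shown sit. Acetoxymethyl in place of methoxy thus shows that a measured value can be obtained with this group at this position, but it puts no size on the change.

The compounds shown leave open whether hydroxymethyl, an amine or a carboxylic acid in the same place would also give a number in this assay. They also leave open how far a longer chain would move the value from that of compound 4.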